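Chloro for methyl in the ethylamino series

This account rests on a few compounds, and the source may have more. Where it says the series, first, only, none or still open, it means among the compounds named here.

Measured so far in an ADME assay on microsomes from liver (Mus musculus) for metabolic stability, read by LC-MS, with a stated time of 30 min, tested at 1 uM (a higher number here means that more of the compound is left, a lower number that less of the compound is left), for two compounds
Compound 1 `CC(C)(C)NCc1cc(Cl)cc(Nc2nc3ccccc3n2Cc2ccc(C(F)(F)F)cc2)c1O` gives 36%
Compound 2 `CCNCc1cc(C)cc(Nc2nc3ccccc3n2Cc2ccc(C(F)(F)F)cc2)c1O` gives 52%

Compound 2 stands at 52% and is the higher of the two, beyond the scatter from compound 1. Compound 3 `CCNCc1cc(Cl)cc(Nc2nc3ccccc3n2Cc2ccc(C(F)(F)F)cc2)c1O` follows from compound 2 with chloro in place of methyl on an aromatic carbon and the chloro para to a hydroxy group. Among the compounds with values here, no measured step isolates this change. Compound 1 also carries chloro and gives 36% so a fall is expected rather than a rise. In this assay the expected change is a number 6 percentage points lower from compound 2 to compound 3 (within the scatter) and this modest fall may stay within the scatter. Compound 3 is expected at 46% within an estimated range from 31% to 61% in this read-out.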

Compound 3, percent of the compound remaining: 73%
Estimate against measurement, compound 3: 27 percentage points below; the whole stated range lies below it.
By their numbers in this assay, from the lowest: compound 1; then compound 2; then compound 3.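

In this assay chloro in place of methyl on the aromatic carbon para to a hydroxy group gives a number 21 percentage points higher from compound 2 to compound 3 (beyond the scatter) with ethyl held on the amine nitrogen. With chloro held in place, ethyl in place of tert-butyl on the amine nitrogen gives a number 37 percentage points higher from compound 1 to compound 3 (beyond the scatter) and so chloro at this position does not by itself bring a low number. Nothing at hand explains either step. Still open, as far as these compounds go, is whether chloro in place of methyl gives a similar step with tert-butyl or an isopropyl group on the amine nitrogen. From the compounds shown here alone, how fluoro or a nitrile would stand at this position is also open.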